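This account rests on a few compounds, and the source may have more. Where it says the series, first, only, none or still open, it means among the compounds named here.

Of the compounds shown here, two of a shared core have been measured in a functional assay on Ramos cells (Homo sapiens) for antiproliferative activity, read by CCK-8 assay, with a stated time of 72 h, tested at 40 uM; on this read-out higher numbers stand for more inhibition at the one concentration tested (going by the name of the read-out) and lower numbers for less inhibition. Compound 1 `CCOC(=O)c1sc(-c2cccc(NC(=O)c3ccccc3)c2)nc1Nc1ccc(N2CCN(C)CC2)cc1` carries an ethyl ester, and in this assay compound 1 gives 77.1%. Compound 2 `CN1CCN(c2ccc(Nc3nc(-c4cccc(NC(=O)c5ccccc5)c4)sc3C(=O)O)cc2)CC1` is its free acid, and in this assay compound 2 gives 26.3%, the lowest of the two numbers seen. For the measured compounds named here, the one step recorded so far, a number 50.8 percentage points lower from compound 1 to compound 2 (beyond the scatter), concerns the ester-to-acid exchange and says nothing about the benzamido end of the molecule.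

Compound 3 `CN1CCN(c2ccc(Nc3nc(-c4cccc(NC(=O)c5ccccc5F)c4)sc3C(=O)O)cc2)CC1` keeps the free acid of compound 2 and differs only there: fluoro in place of hydrogen on an aromatic carbon. Going by the values given here, no measured step touches this position, so there is no basis for expecting a change beyond the scatter in this assay. The estimate for compound 3 is therefore 30%, with a range of 10% to 55%, meaning an expected step of a number 3.7 percentage points higher from compound 2 to compound 3 (within the scatter).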

Compound 3, a percentage reported as inhibition, at one concentration (the size of the read-out at that concentration, not a potency): 93.4%
Compound 3: middle estimate off by 63.4 percentage points, on the low side; measured number above the stated range.
By their numbers in this assay, from the lowest: compound 2; then compound 1; then compound 3.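

In this assay, fluoro in place of hydrogen on the benzoyl ring gives a number 67.1 percentage points higher from compound 2 to compound 3 (beyond the scatter), so this ring position, ortho to a large group, strongly affects the read-out even though the change adds only one heavy atom. Compound 3 keeps the free acid, which shows that the acid does not by itself fix a low number on this core. No measurement here explains why this single atom has so large an effect.

The compounds shown leave open whether this step is particular to fluoro or would also appear with chloro or methoxy at the same place, or with fluoro elsewhere on the ring. They also leave open whether the 2-fluorophenyl group would change the number of the ethyl ester, compound 1, to a similar extent.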